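The source may hold more compounds than are shown below. What is called first, only, known or untested is meant among the compounds shown, and "the series" means these compounds.

Among the measured compounds shown here, in an ADME assay for permeability, using PAMPA, with a stated time of 4 h, at pH 7.4 (on this read-out higher numbers stand for higher permeability and lower numbers for lower permeability), compound 2 (`N[C@H]1CC[C@H](N(C[C@H]2Cc3ccccc3CN2)[C@H]2CCCc3cccnc32)CC1`) gives 37 nm/s, the higher of the two numbers so far, while compound 1 (`C/C(=C/CN(C[C@H]1Cc2ccccc2CN1)[C@H]1CCCc2cccnc21)CN`) gives 11 nm/s. Compound 3 (`C/C(=C/CN)CN(C[C@H]1Cc2ccccc2CN1)[C@H]1CCCc2cccnc21`) gives up the 4-aminocyclohexyl group on an amine nitrogen for a group with no ring: a group of 6 heavy atoms (5 carbon, 1 nitrogen; no ring) in place of a group of 7 heavy atoms (6 carbon, 1 nitrogen; one six-membered non-aromatic ring of carbon only), on an amine nitrogen. For the measured compounds named here, one measured step bears on this, a 3.4-fold higher number from compound 1 to compound 2 (0.53 log units; beyond the scatter), a modest change beyond the scatter in which a ring-free group made way for that ring group. The ring-free group of compound 3 is not identical to that of compound 1, so the guide is imperfect. A drop of similar size is expected, an estimated 2.8-fold lower number from compound 2 to compound 3 (0.45 log units; beyond the scatter). The expected value for compound 3 is 13 nm/s, with an estimated range of 6 nm/s to 28 nm/s.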

Compound 3, apparent permeability: 250 nm/s
Estimate against measurement, compound 3: 19-fold (1.28 log units) below; the whole stated range lies below it.
By their numbers in this assay, from the lowest: compound 1; then compound 2; then compound 3.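

In this assay, a ring-free group on this amine nitrogen does not fix the direction of change against the 4-aminocyclohexyl group: compound 1 stands lower, yet the swap gives a 6.8-fold higher number from compound 2 to compound 3 (0.83 log units; beyond the scatter). Rearranging the ring-free group while keeping its carbon and nitrogen counts gives a 23-fold higher number from compound 1 to compound 3 (1.36 log units; beyond the scatter), so the arrangement of its atoms matters, not just the absence of a ring. Nothing at hand explains this difference. As far as these compounds go, what the double bond contributes stays open, and a saturated chain ending in an amine on the same nitrogen would test it.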